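A few compounds are considered here, and "the series" means these few. Any claim that something is new, unique, unknown or untested is made for them only; others in the source may bear on it.

Series notes. Of the compounds shown here, two have been read in a functional assay on EC9706 cells (Homo sapiens) for cytotoxicity, read by MTT assay, with a stated time of 72 h (on this read-out higher numbers stand for weaker inhibition and lower numbers for stronger inhibition), so far. Compound 1 `CCCCCCCCSC(=S)N[C@H]1CCOC1=O` gives > 128000 nM, which is a limit of the assay and not a number. For the measured compounds named here, compound 2 `O=C(CCl)Nc1ccc(C(=O)/C=C/c2ccc(Br)cc2)cc1` gives 10100 nM, the only actual number in hand, so it has no measured neighbour to be ranked against.

The next compound is compound 3 `O=C(CCl)Nc1ccc(C(=O)/C=C/c2cccc(Cl)c2)cc1`, which keeps the chloroacetamide side of compound 2 and alters the other end. It carries 3-chlorophenyl in place of 4-bromophenyl on a double-bonded chain carbon bound to a double-bonded chain carbon.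

Going by the values given here, no measured pair shows what a swap of this kind does in this assay. The expectation therefore stays anchored on compound 2 at 10100 nM, with no direction favoured. The expected step is a 1.1-fold lower number from compound 2 to compound 3 (0.03 log units; within the scatter), which would stay within the usual scatter. The range is kept wide because it rests on a single number. For compound 3 the estimate is 9500 nM, with an expected range from 3500 nM to 26000 nM.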

Compound 3, half-maximal inhibitory concentration: 5560 nM
Beside the measured number, compound 3's estimate is 1.7-fold (0.23 log units) above it; measured number inside the range.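

In this assay, for the compounds shown here, the first readable step at this place, 3-chlorophenyl in place of 4-bromophenyl on a double-bonded chain carbon bound to a double-bonded chain carbon, gives a 1.8-fold lower number from compound 2 to compound 3 (0.26 log units; within the scatter). With the chloroacetamide side held constant, this exchange therefore leaves the two compounds indistinguishable on this read-out, although the halogen and its ring position differ together, so this single step cannot separate the two changes. Nothing in hand bears on a cause for this result.

Still open, from the compounds shown here alone, is whether a phenyl ring carrying an amine or a carboxylic acid at this place, or an unsubstituted phenyl, would give a step beyond the scatter, and whether 3-bromophenyl or 4-chlorophenyl would separate the halogen from its ring position. Also open, going by these compounds, is what the chloroacetamide side contributes, since compound 2 and compound 3 share it and a plain acetamide would be the direct test of its chlorine.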